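The source may hold more compounds than are shown below. What is called first, only, known or untested is meant among the compounds shown, and "the series" means these compounds.

Measured so far:
compound 1, `CC(=O)N[C@@H]1CCC[C@H](C(=O)Nc2cc(-c3cnn4ccccc34)c(Cl)cn2)C1`, 3.6 in a physicochemical assay for lipophilicity, using the shake flask method, measured as octanol-water partition, at pH 7.4; on this read-out lower numbers stand for lower lipophilicity and higher numbers for higher lipophilicity
compound 2, `CC(=O)N[C@@H]1CCC[C@H](C(=O)Nc2cc(-c3cnn4c3NCCC4)c(Cl)cn2)C1`, 2.4 in this assay

Going by the values given here, compound 2 has the lower of the two numbers; compound 1 sits higher by a margin beyond the scatter, as the single step of a number 1.20 log units lower from compound 1 to compound 2 (beyond the scatter) shows.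

Compound 3, `CC(=O)N[C@@H]1CCC[C@H](C(=O)Nc2cc(-c3cnn4c3CC(C)(C)C4)c(Cl)cn2)C1`, has not yet been measured. The change from compound 2 is a group of 10 heavy atoms (8 carbon, 2 nitrogen; one five-membered non-aromatic ring with 1 hetero atom, one five-membered aromatic ring with 2 hetero atoms) in place of a group of 9 heavy atoms (6 carbon, 3 nitrogen; one five-membered aromatic ring with 2 hetero atoms, one six-membered non-aromatic ring with 2 hetero atoms), on an aromatic carbon. Among the compounds with values here, the one measured step, from compound 1 to compound 2, bears on it only partly: it traded an aromatic six-membered ring for a non-aromatic one carrying a hydrogen-bond donor and a third nitrogen, and it moved the number by a large amount. The change to compound 3 removes that donor and nitrogen again and brings in a non-aromatic ring of carbons with two extra methyls, so a step back upward, of a size comparable to that of the measured step, is expected: a number 1.30 log units higher from compound 2 to compound 3 (beyond the scatter). Compound 3 is therefore estimated at 3.7, within 3.2 to 4.2.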

Compound 3, distribution coefficient: 3.8
Estimate against measurement, compound 3: 0.10 log units below, and the stated range covers the measured number.
By their numbers in this assay, from the lowest: compound 2; then compounds 1 and 3 (each within the scatter of the next).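

In this assay this position, opposite the ring nitrogen and ortho to the chloro group, proves highly responsive to the make-up of the attached group: the group with a five-membered non-aromatic ring and no hydrogen-bond donor gives a number 1.40 log units higher from compound 2 to compound 3 (beyond the scatter). A non-aromatic ring does not by itself go with a low number, since the step of a number 0.20 log units higher from compound 1 to compound 3 (within the scatter) leaves compound 3 level with the group carrying the six-membered aromatic ring, and among the compounds shown only compound 2, with its hydrogen-bond donor and third nitrogen, stands apart. No measurement available here accounts for these shifts.

The step from compound 2 to compound 3 changes ring size, nitrogen count and methyl substitution at once, so their separate shares remain unresolved. Also open, as far as these compounds go, is where the same five-membered ring without its methyl groups, or the six-membered ring with a methyl on its amine nitrogen, would fall.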